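Swapping a Methyl for Bromo on the Fused Ring

This account rests on a few compounds, and the source may have more. Where it says the series, first, only, none or still open, it means among the compounds named here.

Compound 1 `Cc1cc(C)c2c(c1)CN(c1ccc3c(=O)cc(-c4ccccc4)oc3c1)CO2` gives 48.4%.
Compound 2 `O=c1cc(-c2ccccc2)oc2cc(N3COc4c(cccc4[N+](=O)[O-])C3)ccc12` gives 15.7%.
Compound 3 `Cc1cccc2c1OCN(c1ccc3oc(-c4ccccc4)cc(=O)c3c1)C2` gives 85.1%.

All three share a core and were tested in a functional assay on MCF7 cells (Homo sapiens) for inhibition, read by MTT assay, with a stated time of 48 h, tested at 60 ug/mL; on this read-out lower numbers stand for less inhibition of growth and higher numbers for more inhibition of growth at the one concentration tested. Compound 3 stands highest of the three numbers; compound 1 comes nearest, lower by a margin beyond the usual scatter, and compound 2 lies furthest, also beyond the scatter. Compound 4 `O=c1cc(-c2ccccc2)oc2ccc(N3COc4c(Br)cccc4C3)cc12` has not yet been tested in this assay. It differs from compound 3 in one place: bromo in place of methyl on an aromatic carbon. Going by the values given here, no step between two measured compounds that differ in a single place is known here, so there is no directly comparable change to lean on. A modest step is expected, more likely downward than upward, though one within the scatter would not surprise. For compound 4 the estimate in this assay is 68%, between 38% and 92%. This estimate means an expected step of a number 17.1 percentage points lower from compound 3 to compound 4 (beyond the scatter).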

Compound 4, percent growth inhibition at one concentration: 81.8%
Compound 4: middle estimate off by 13.8 percentage points, on the low side, and the stated range covers the measured number.
By their numbers in this assay, from the lowest: compound 2; then compound 1; then compounds 4 and 3 (each within the scatter of the next).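

In this assay, going by these compounds alone, bromo in place of methyl on this aromatic carbon gives a number 3.3 percentage points lower from compound 3 to compound 4 (within the scatter) as the first step between two compounds that differ in one place. At this carbon, ortho to a fused ring and meta to a fused ring, the read-out does not tell the two groups apart. No measurement here offers an explanation for this. On these data alone, whether an amine, a carboxylic acid or a longer chain on this same carbon would give a similar number stays open. So does whether the same swap on another carbon of this ring would behave alike.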